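Aromatic methyl step across two cores

The source may hold more compounds than are shown below. What is called first, only, known or untested is meant among the compounds shown, and "the series" means these compounds.

Measured compounds:
- compound 1 `COC(=O)[C@@]1(C)CCC=C2[C@@H]1CC[C@@H](C)[C@]2(C)Cc1c[nH]c2ccc(C)cc12` gives 14000 nM in a functional assay on HeLa cells (Homo sapiens) for inhibition, read by sulforhodamine B assay, with a stated time of 48 h; on this read-out higher numbers stand for weaker inhibition of growth and lower numbers for stronger inhibition of growth
- compound 2 `COC(=O)[C@@]1(C)CCC=C2[C@@H]1CC[C@@H](C)[C@]2(C)Cc1c(C)[nH]c2ccc(C)cc12` gives 17000 nM in this assay
- compound 3 `COC(=O)[C@@]1(C)CC[C@@H]2C3=C1CC[C@@H](C)[C@]3(C)C[C@@H]1c3ccccc3N[C@H]21` gives 19000 nM in this assay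

From compound 1 to compound 2 the change is methyl in place of hydrogen on an aromatic carbon and the step was a 1.2-fold higher number from compound 1 to compound 2 (0.08 log units; within the scatter). The difference between the core of compound 1 and the core of compound 3 is not broken down here; the values of compound 3 and compound 1 lie within the scatter of each other, as do those of compound 3 and compound 2.

Compound 4 `COC(=O)[C@@]1(C)CC[C@@H]2C3=C1CC[C@@H](C)[C@]3(C)C[C@@H]1c3cc(C)ccc3N[C@H]21` is not yet measured. It differs from compound 3 by methyl in place of hydrogen on an aromatic carbon. This is the same kind of change as from compound 1 to compound 2, not the same: there the methyl entered on a five-membered aromatic ring with 1 nitrogen, next to the ring nitrogen and next to the ring atom that bears a large group, whereas here it enters on a six-membered aromatic ring of carbon only, meta to a fused ring and para to a fused ring.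

Going by the values given here, the step from compound 3 to compound 4 is expected to be small, a 1.2-fold higher number from compound 3 to compound 4 (0.06 log units; within the scatter), resting on the single earlier step of a 1.2-fold higher number from compound 1 to compound 2 (0.08 log units; within the scatter). Compound 4 is therefore estimated at 22000 nM, with a range from 10000 nM to 45000 nM.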

Compound 4, concentration for 50% growth inhibition: 18000 nM
Compound 4: the middle estimate sits 1.2-fold (0.09 log units) above what was measured; the range from low to high includes it.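

In this assay methyl in place of hydrogen on an aromatic carbon gives a 1.1-fold lower number from compound 3 to compound 4 (0.02 log units; within the scatter) on the core of compound 3. Set beside the earlier step on the core of compound 1, the change reads the same on both cores as far as this read-out can tell: the same change on two cores in this assay, a 1.2-fold higher number (0.08 log units; within the scatter) from compound 1 to compound 2 and a 1.1-fold lower number (0.02 log units; within the scatter) from compound 3 to compound 4, 1.3-fold (0.11 log units) apart, within the scatter of two such steps. Going by these compounds alone, this shows only that two methyl steps, each within the scatter, agree with each other; it does not show that a larger effect would carry from one core to the other, since neither step is large enough to test that, nor that the two ring positions are equivalent.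

Left open is whether a different group on the same aromatic carbon, such as an amine, a carboxylic acid or a longer chain, would move the number beyond the scatter on either core. Also open, on these data alone, is what replacing the methyl ester shared by all four compounds, for example with a carboxylic acid or an amide, would do to growth inhibition.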